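This account rests on a few compounds, and the source may have more. Where it says the series, first, only, none or still open, it means among the compounds named here.

Measured compounds:
compound 1, `COc1ccc(-c2ccnc(C(=O)Nc3ccc(Oc4ccnc5[nH]ccc45)cc3)n2)cc1`, in a functional assay on PC-3 cells (Homo sapiens) for cytotoxicity, read by MTT assay, with a stated time of 72 h (a lower number here means a stronger inhibitor, a higher number a weaker inhibitor), compound 1 gives 17300 nM.
compound 2, `O=C(Nc1ccc(Oc2ccnc3[nH]ccc23)cc1)c1nccc(-c2ccc(Cl)cc2)n1`, in this assay compound 2 gives "not active" (no number reported).
compound 3, `O=C(Nc1ccc(Oc2ccnc3[nH]ccc23)cc1)c1nccc(-c2ccc(F)cc2)n1`, in this assay compound 3 gives "not active" (no number reported).

Compound 2 has no single number in this assay; compound 3 is the other entry without one, and only compound 1 carries a number, itself a weak one. Compound 4, `O=C(Nc1ccc(Oc2ccnc3[nH]ccc23)c(F)c1)c1nccc(-c2ccc(Cl)cc2)n1`, differs from compound 2 by fluoro in place of hydrogen on an aromatic carbon. For the measured compounds named here, no measured pair in this set shows such a change, so the size and direction of the step are unknown; given that compound 2 reports no activity, nothing here suggests a shift beyond the scatter. Compound 4 is therefore expected to remain weak in this assay, estimated at 40000 nM within 10000 nM to 200000 nM, with a real chance that again only an inactive result is reported.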

Compound 4, half-maximal inhibitory concentration: 14600 nM
For compound 4 the middle estimate is 2.7-fold (0.44 log units) above the measured one, and the stated range covers the measured number.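

For the compounds shown here, compound 2 has no number in this assay, so no step from it to compound 4 can be read. The compounds shown leave open what fluoro in place of hydrogen does to a measured value, and nothing available explains the result of compound 4.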